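The source may hold more compounds than are shown below. What is called first, only, known or untested is meant among the compounds shown, and "the series" means these compounds.

Working notes on the series:

- Compound 1 `C=CS(=O)(=O)N1CCN(c2ncnc3sc(-c4cccs4)cc23)CC1`: 34100 nM
- Compound 2 `CN1CCN(c2ccc(-c3cc4c(N5CCN(S(=O)(=O)/C=C/c6ccccc6)CC5)ncnc4s3)cc2)CC1`: 5900 nM
- Compound 3 `CCCNC(=O)N1CCN(c2ncnc3sc(-c4ccc(N5CCN(C)CC5)cc4)cc23)CC1`: 8330 nM
- Compound 4 `CN1CCN(c2ccc(-c3cc4c(N5CCN(C(=O)Nc6ccccc6F)CC5)ncnc4s3)cc2)CC1`: not yet measured

In a functional assay on MDA-MB-231 cells (Homo sapiens) for antiproliferative activity, read by MTT assay, with a stated time of 48 h (a higher number here means a weaker inhibitor, a lower number a stronger inhibitor), compound 3 gives 8330 nM, second highest of the three numbers and within the scatter of compound 2. Compound 4 follows from compound 3 by one change: 2-fluorophenyl in place of propyl on an amide-type nitrogen. For the measured compounds named here, one measured step bears on this, a 1.4-fold higher number from compound 2 to compound 3 (0.15 log units; within the scatter), which swaps (2-phenylethenyl)sulfonyl for propylcarbamoyl on the same ring nitrogen and stays within the scatter. Going by the values given here, no measured compound carries a (2-fluorophenyl)carbamoyl group, so this is indirect evidence, and no step beyond the scatter is expected in this assay. The expected change is a 1.4-fold lower number from compound 3 to compound 4 (0.14 log units; within the scatter). For compound 4 the estimate is 6000 nM, with an expected range of 2200 nM to 16000 nM.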

Compound 4, half-maximal inhibitory concentration: 10300 nM
For compound 4 the middle estimate is 1.7-fold (0.23 log units) below the measured one; measured number inside the range.
By their numbers in this assay, from the lowest: compounds 2, 3 and 4 (each within the scatter of the next); then compound 1.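

On the amide-type nitrogen, 2-fluorophenyl in place of propyl gives a 1.2-fold higher number from compound 3 to compound 4 (0.09 log units; within the scatter) in this assay, so an aromatic ring and an open chain at this place are not told apart. The wider exchange of (2-phenylethenyl)sulfonyl for (2-fluorophenyl)carbamoyl on the ring amine nitrogen gives a 1.7-fold higher number from compound 2 to compound 4 (0.24 log units; within the scatter), so compounds 2, 3 and 4 all read alike here. Nothing available accounts for this flat reading.

Open, on these data alone, is whether phenyl without fluorine, a carboxylic acid or a longer chain on that amide-type nitrogen would give a step beyond the scatter.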